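Oxanyl in place of cyclopropyl on the pyrazole nitrogen

The compounds below may be only part of what the source reports. "The series", "measured", "known", "first", "only" and "open" are said of these compounds alone.

Measured in an assay on RAW264.7 cells for inhibition of serine/threonine-protein kinase TBK1 (Mus musculus), read by ELISA, with stated times of 30 min and 6 h; on this read-out lower numbers stand for stronger inhibition and higher numbers for weaker inhibition:
Compound 1 `CC(C)n1cc(Nc2ncc(C3CC3)c(NCCCNC(=O)C3CCC3)n2)cn1` gives 81 nM.
Compound 2 `O=C(NCCCNc1nc(Nc2cccnc2)ncc1C1CC1)C1CCC1` gives > 1000 nM, which is a limit of the assay and not a number.
Compound 3 `O=C(NCCCNc1nc(Nc2cnn(C3CC3)c2)ncc1C1CC1)C1CCC1` gives 130 nM.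

Of the two numbers, compound 3 holds the higher one, yet compound 1 lies within the scatter of it. Compound 4 `O=C(NCCCNc1nc(Nc2cnn(C3CCOCC3)c2)ncc1C1CC1)C1CCC1` differs from compound 3 by oxan-4-yl in place of cyclopropyl on an aromatic nitrogen. The step that bears on this change sits at the same position: a 1.6-fold higher number from compound 1 to compound 3 (0.21 log units; within the scatter), a step within the scatter. The larger steps, an at least 12-fold higher number from compound 1 to compound 2 (1.09 log units; beyond the scatter) and an at least 7.6-fold lower number from compound 2 to compound 3 (0.88 log units; beyond the scatter), concern the exchange of the whole ring rather than the group on its nitrogen. One value sits at the limit of > 1000 nM in this assay, at which 1 of the 3 values shown sits. For compound 4 a change within the scatter is therefore expected in this assay, a 1.2-fold higher number from compound 3 to compound 4 (0.06 log units; within the scatter). Compound 4 is estimated at 150 nM, in the range 50 nM to 450 nM.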

Compound 4, half-maximal inhibitory concentration: 280 nM
Beside the measured number, compound 4's estimate is 1.9-fold (0.27 log units) below it, within the range that was stated.
By their numbers in this assay, from the lowest: compounds 1 and 3 (each within the scatter of the next); then compound 4. At a limit, above all of these: compound 2.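

In this assay, the group on this aromatic nitrogen now makes a difference beyond the scatter: the step is a 2.2-fold higher number from compound 3 to compound 4 (0.33 log units; beyond the scatter) and a 3.5-fold higher number from compound 1 to compound 4 (0.54 log units; beyond the scatter), whereas cyclopropyl and isopropyl had stayed within the scatter of each other. Oxan-4-yl is thus accepted here, but at a modest cost. The data do not tell whether the size of the group or its ring oxygen accounts for this step. From the compounds shown here alone, it remains open whether cyclohexyl, with carbon in place of that oxygen, or piperidin-4-yl, with a ring amine there, would stand with compound 3 or with compound 4.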